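A few compounds are considered here, and "the series" means these few. Any claim that something is new, unique, unknown or untested is made for them only; others in the source may bear on it.

Measured so far in an assay on isolated protein for inhibition of MAP kinase-interacting serine/threonine-protein kinase 1 (Homo sapiens); a lower number here means a stronger inhibitor, a higher number a weaker inhibitor:
compound 1, `COC(=O)c1ccc(Nc2[nH]cnc3ncnc2-3)cc1`: 850 nM
compound 2, `OCCNc1ccc2ncc(-c3ccc(Cl)cc3)n2n1`: 2930 nM

In this assay compound 2 stands highest of the two numbers; the nearest is compound 1, whose number is lower by a gap beyond the usual scatter. Among the compounds with values here, the two compounds share no single point of difference, so the pair yields no step that can be read across.

Compound 3 is `COCCNc1ccc2ncc(-c3ccc(Cl)cc3)n2n1`, not yet measured in this assay. Against compound 2 the change is methyl in place of hydrogen on an oxygen on a saturated carbon; the same difference, cut one bond further out, reads hydroxy to methoxy, hydroxymethyl to methoxymethyl, 2-hydroxyethyl to 2-methoxyethyl. Within the data shown here, no measured pair carries this change, so nothing here sets its size or direction. For a change of this kind the expected step from compound 2 to compound 3, a 1.0-fold higher number from compound 2 to compound 3 (0.01 log units; within the scatter), is none beyond the scatter, with either direction left open. Compound 3 is therefore estimated at 3000 nM in this assay, with a range from 1200 nM to 7500 nM.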

Compound 3, half-maximal inhibitory concentration: 1620 nM
Beside the measured number, compound 3's estimate is 1.9-fold (0.27 log units) above it, and the stated range covers the measured number.
By their numbers in this assay, from the lowest: compounds 1, 3 and 2 (each within the scatter of the next, the first and the last beyond it).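

In this assay, within the data shown here, the only step that can be read so far, methyl in place of hydrogen on an oxygen on a saturated carbon, gives a 1.8-fold lower number from compound 2 to compound 3 (0.26 log units; within the scatter) and is the first direct reading at this position. Going from 2-hydroxyethyl to 2-methoxyethyl therefore removes the hydrogen on that oxygen without a shift beyond the scatter, so in this single pair inhibition of the kinase does not depend measurably on that hydrogen. Nothing on hand explains this outcome or shows how the two compounds compare in any respect other than this read-out.

Still open, going by these compounds, is how far this holds: one pair cannot show whether an ethoxy group, a longer chain, or an amine or carboxylic acid at the end of the chain would also stay within the scatter. On these data alone, compound 1 differs from compound 2 and compound 3 in more than one place, so the shared core of these two cannot yet be compared with it, and the effect of changing the chain on any other core also remains unknown.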